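The compounds below may be only part of what the source reports. "The series", "measured", "known", "first", "only" and "open" are said of these compounds alone.

Compound 1 `Cc1cccc2c1nc(-c1c(F)cccc1F)n2Cc1c(F)cccc1F` was examined in a toxicity assay on CCRF-CEM cells (Homo sapiens) for cytotoxicity; a higher number here means that more compound is tolerated, a lower number that less compound is tolerated. In this assay compound 1 reaches only a limit, > 100 uM, so where it stands rests on (the limit of > 100 uM in this assay, at which 1 of the 3 values shown sits). Compound 2 `CCc1cccc2c1nc(-c1c(F)cccc1F)n2Cc1c(F)cccc1F` gives 26.1 uM in this assay, and compound 3 `Fc1cccc(F)c1Cn1c(-c2c(F)cccc2F)nc2c(Cl)cccc21` gives 30.4 uM. The step of an at least 3.8-fold lower number from compound 1 to compound 2 (0.58 log units; beyond the scatter) concerns the same place as the change now followed, and an at least 3.2-fold lower number from compound 1 to compound 3 (0.51 log units; beyond the scatter) runs the same way through a change on an aromatic carbon, while a 1.2-fold higher number from compound 2 to compound 3 (0.07 log units; within the scatter) separates those two endpoints only slightly. Compound 4 `NCc1cccc2c1nc(-c1c(F)cccc1F)n2Cc1c(F)cccc1F` differs from compound 1 by amino in place of hydrogen on a saturated chain carbon bound to an aromatic carbon. Guided by an at least 3.8-fold lower number from compound 1 to compound 2 (0.58 log units; beyond the scatter) at the same place, compound 4 is expected at 60 uM, within 20 uM to 150 uM. The expected step is an at least 1.6-fold lower number from compound 1 to compound 4 (0.22 log units; that floor lies within the scatter), though a limit again is possible.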

Compound 4, half-maximal toxic concentration: 49.3 uM
For compound 4 the middle estimate is 1.2-fold (0.09 log units) above the measured one; the range from low to high includes it.
By their numbers in this assay, from the lowest: compounds 2, 3 and 4 (each within the scatter of the next). At a limit, above all of these: compound 1.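

In this assay, an at least 2.0-fold lower number from compound 1 to compound 4 (0.30 log units; that floor lies within the scatter), a floor that, unlike the step to the ethyl compound, does not clear the scatter. Compound 1 stands at a limit: the limit of > 100 uM in this assay, at which 1 of the 4 values shown sits. Aminomethyl is also not told apart from ethyl or chloro at this position, with a 1.9-fold higher number from compound 2 to compound 4 (0.28 log units; within the scatter) and a 1.6-fold higher number from compound 3 to compound 4 (0.21 log units; within the scatter).

From the compounds shown here alone, the true size of the steps from compound 1 remains open. So does whether a carboxylic acid or a dimethylamine on this chain would read like compound 4 or like compound 1.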